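A few compounds are considered here, and "the series" means these few. Any claim that something is new, unique, unknown or untested is made for them only; others in the source may bear on it.

Going by the values given here, in a functional assay on PC-3 cells (Homo sapiens) for cytotoxicity, read by MTT assay, with a stated time of 72 h (on this read-out lower numbers stand for stronger inhibition and higher numbers for weaker inhibition), compound 1 `CCCOCNc1n[n+]([O-])c2cc(OC)ccc2[n+]1[O-]` gives 6570 nM, the lower of the two numbers so far, while compound 2 `CCCOCNc1n[n+]([O-])c2ccccc2[n+]1[O-]` gives 14200 nM. The untested compound 3 `COc1ccc2c(c1)[n+]([O-])nc(NCOCc1ccccc1)[n+]2[O-]` keeps the core of compound 1 and alters only the chain: phenyl in place of ethyl on a saturated chain carbon bound to an oxygen on a saturated carbon, which turns propoxy into benzyloxy. Among the compounds with values here, no measured step touches this chain. The only one, a 2.2-fold higher number from compound 1 to compound 2 (0.33 log units; beyond the scatter), swaps methoxy for hydrogen and serves merely as a gauge of size. With no firm direction, the estimated step is a 1.1-fold lower number from compound 1 to compound 3 (0.04 log units; within the scatter). For compound 3 the expected value is 6000 nM, within an estimated range of 2500 nM to 16000 nM.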

Compound 3, half-maximal inhibitory concentration: 8580 nM
Compound 3: middle estimate off by 1.4-fold (0.16 log units), on the low side; the range from low to high includes it.
By their numbers in this assay, from the lowest: compounds 1, 3 and 2 (each within the scatter of the next, the first and the last beyond it).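

Swapping ethyl for phenyl on a saturated chain carbon bound to an oxygen on a saturated carbon gives, in this assay, a 1.3-fold higher number from compound 1 to compound 3 (0.12 log units; within the scatter) as the first measured change to this chain. Turning propoxy into benzyloxy thus adds a six-membered aromatic ring without a change in the number beyond the usual scatter. Nothing measured here explains this result.

As far as these compounds go, whether an amine, a carboxylic acid or a longer chain in place of phenyl would shift the number remains open. Also open, from the compounds shown here alone, is how benzyloxy behaves on the core of compound 2, which has hydrogen in place of methoxy.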